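Lactam in place of the piperidine: expected solubility of compound 4

The source may report more compounds than this note shows. Statements on the series, on what has been measured and on what is new or still open speak of the compounds shown alone.

Working notes on the series. Among the measured compounds shown here, compound 3 `CN1CCC(NC(=O)c2ccncc2Nc2cc(-c3ccc4ccn(C)c4c3)c3nccnc3c2)CC1` gives 246 ug/mL in a physicochemical assay for solubility, read by spectrophotometry, measured as kinetic solubility, at pH 8, tested at 500 uM (a higher number here means a more soluble compound, a lower number a less soluble compound), the highest of the three numbers so far. Compound 1 `Cn1ccc2ccc(-c3cc(Nc4cnccc4C(=O)NCc4cncnc4)cc4nccnc34)cc21` gives 233 ug/mL, and the gap a 1.1-fold higher number from compound 1 to compound 3 (0.02 log units; within the scatter) is within the scatter, so the two cannot be ordered. Compound 2 `Cn1cc(NC(=O)c2ccncc2Nc2cc(-c3ccc4ccn(C)c4c3)c3nccnc3c2)cn1` gives 2 ug/mL, and the step of a 120-fold higher number from compound 2 to compound 3 (2.09 log units; beyond the scatter) is large and beyond the scatter, as is a 120-fold lower number from compound 1 to compound 2 (2.07 log units; beyond the scatter).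

Compound 4 `CN1CCC(NC(=O)c2ccncc2Nc2cc(-c3ccc4ccn(C)c4c3)c3nccnc3c2)CC1=O` differs from compound 3 at a single place: 1-methyl-2-oxopiperidin-4-yl in place of 1-methylpiperidin-4-yl on an amide-type nitrogen. For the measured compounds named here, no measured step touches this change. The steps on record all swap the whole group on the amide-type nitrogen, and the two large ones involve the 1-methyl-1H-pyrazol-4-yl of compound 2, which is not in play here. The step from compound 1 to compound 3 shows that two rather different groups at this position can give numbers within the scatter of each other. With nothing measured that bears on the oxo group, the expectation for this assay is a modest lower number, possibly none beyond the scatter, with wide uncertainty: a 2.2-fold lower number from compound 3 to compound 4 (0.35 log units; beyond the scatter) is the expected step. Compound 4 is therefore estimated at 110 ug/mL in this assay, in the range 20 ug/mL to 250 ug/mL.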

Compound 4, solubility: 48 ug/mL
For compound 4 the middle estimate is 2.3-fold (0.36 log units) above the measured one; low and high end bracket the measured number.
By their numbers in this assay, from the lowest: compound 2; then compound 4; then compounds 1 and 3 (each within the scatter of the next).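

In this assay, the position on the amide-type nitrogen responds to a change within one group as well as to a swap of the whole group: 1-methyl-2-oxopiperidin-4-yl in place of 1-methylpiperidin-4-yl gives a modest step (a 5.1-fold lower number from compound 3 to compound 4 (0.71 log units; beyond the scatter)), although both groups carry the same counts of hydrogen-bond donors and acceptors. Compounds 1 and 3 could not be ordered, but compound 4 separates from compound 1 by a step of similar size (a 4.9-fold lower number from compound 1 to compound 4 (0.69 log units; beyond the scatter)). Compound 4 also remains well clear of compound 2 (a 24-fold higher number from compound 2 to compound 4 (1.38 log units; beyond the scatter)), so the groups at this position now give three distinct levels rather than two.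

Nothing in the data on this series explains the step from the 1-methylpiperidin-4-yl to the 1-methyl-2-oxopiperidin-4-yl group. On these data alone, it remains open whether a piperidin-4-yl group without the 1-methyl, a morpholine or a carboxylic acid on this amide-type nitrogen would give a number near that of compound 3, near that of compound 4, or somewhere else.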